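The source may hold more compounds than are shown below. What is called first, only, known or untested is meant among the compounds shown, and "the series" means these compounds.

Compound 1, `Cc1cccc(C2=CCN(C(=O)[C@H]3NCC4(CC4)C[C@@H]3C(=O)NO)CC2)c1`: 25 nM
Compound 2, `CCc1cccc(C2=CCN(C(=O)[C@H]3NCC4(CC4)C[C@@H]3C(=O)NO)CC2)c1`: 33 nM
Compound 3, `COc1cccc(C2=CCN(C(=O)[C@H]3NCC4(CC4)C[C@@H]3C(=O)NO)CC2)c1`: 40 nM

These three share one core and differ only in the small group carried by the aromatic ring. In an assay on isolated protein for binding affinity to disintegrin and metalloproteinase domain-containing protein 10 (Homo sapiens) (a higher number here means a weaker inhibitor, a lower number a stronger inhibitor), compound 3 gives 40 nM; its steps to the other two, a 1.6-fold higher number from compound 1 to compound 3 (0.20 log units; within the scatter) and a 1.2-fold higher number from compound 2 to compound 3 (0.08 log units; within the scatter), both lie within the scatter, as does a 1.3-fold higher number from compound 1 to compound 2 (0.12 log units; within the scatter), so the three numbers cannot be told apart. Compound 4, `O=C(NO)[C@H]1CC2(CC2)CN[C@@H]1C(=O)N1CC=C(c2cc(Cl)cc(Cl)c2)CC1`, is not yet measured; it differs from compound 3 by 3,5-dichlorophenyl in place of 3-methoxyphenyl on a double-bonded ring carbon. Going by the values given here, the measured steps that changed this aromatic ring stayed within the scatter, and no measured step introduces chlorine. The expected change in this assay is therefore none beyond the scatter, no change at the digits printed from compound 3 to compound 4 (within the scatter). Compound 4 is estimated at 40 nM, with a range from 13 nM to 120 nM.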

Compound 4, half-maximal inhibitory concentration: 99 nM
Compound 4: middle estimate off by 2.5-fold (0.39 log units), on the low side; the range from low to high includes it.
By their numbers in this assay, from the lowest: compounds 1, 2 and 3 (each within the scatter of the next); then compound 4.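

In this assay the aromatic group on this double-bonded ring carbon does affect the number: a 2.5-fold higher number from compound 3 to compound 4 (0.39 log units; beyond the scatter) and a 3.0-fold higher number from compound 2 to compound 4 (0.48 log units; beyond the scatter) and a 4.0-fold higher number from compound 1 to compound 4 (0.60 log units; beyond the scatter) all lie beyond the scatter, unlike the exchanges among methyl, ethyl and methoxy. This change brings in two chlorine atoms and removes the earlier single group at once, so the compounds shown cannot separate those two parts. Nothing available explains the shift. Still open, on these data alone, is whether a single chlorine on the aromatic ring would give the same step, and how an amine or a carboxylic acid there would fare.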